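Halogen swap on the acetylated analogue in the writhing test

The compounds below may be only part of what the source reports. "The series", "measured", "known", "first", "only" and "open" are said of these compounds alone.

Measured so far:
Compound 1, `Clc1ccc2[nH]cc(SC3CCNCC3)c2c1`: 0.3 mg/kg
Compound 2, `CC(=O)N1CCC(Sc2c[nH]c3ccc(Cl)cc23)CC1`: 2.9 mg/kg

Going by the values given here, in a functional assay on the whole organism with Mus musculus as the target, in the writhing test (on this read-out lower numbers stand for an effect already at smaller amounts and higher numbers for an effect only at larger amounts of compound), compound 2 stands at the higher of the two numbers; compound 1 sits at the lower one, and the step of a 9.7-fold higher number from compound 1 to compound 2 (0.99 log units; beyond the scatter) is the only measured step in the set. Compound 3, `CC(=O)N1CCC(Sc2c[nH]c3ccc(Br)cc23)CC1`, is not yet measured. Relative to compound 2 the change is bromo in place of chloro on an aromatic carbon. Among the compounds with values here, no measured step bears directly on it: the single step from compound 1 to compound 2 concerns the ring amine, not the halogen, so nothing here shows how a halogen swap moves the numbers. With no evidence of a shift, the expectation for the step from compound 2 to compound 3 in this assay is no change at the digits printed from compound 2 to compound 3 (within the scatter), that is, no change beyond the scatter. Compound 3 is therefore estimated at 2.9 mg/kg, with a range from 1.2 mg/kg to 7 mg/kg.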

Compound 3, dose for half-maximal effect: 2.9 mg/kg
Compound 3: the middle estimate sits on the measured number at the digits printed; the measured number falls inside the stated range.
By their numbers in this assay, from the lowest: compound 1; then compounds 2 and 3 (each within the scatter of the next).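

Bromo in place of chloro on this aromatic carbon gives no change at the digits printed from compound 2 to compound 3 (within the scatter) in this assay, the first measured change at this position of the shared core. The earlier step, a 9.7-fold higher number from compound 1 to compound 2 (0.99 log units; beyond the scatter), concerned only the ring amine nitrogen, so the halogen position had not been tested until now, and with the acetyl group in place these two halogens cannot be told apart on this read-out. Nothing measured on hand accounts for the two halogens reading alike.

As far as these compounds go, whether the same swap reads alike on the free ring amine of compound 1 stays open. Also open, from the compounds shown here alone, is how a smaller or different group at this aromatic carbon, such as fluoro, methoxy or nitrile, would read in this assay.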